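Compound 3 Expected to Remain at the Assay Limit

A few compounds are considered here, and "the series" means these few. Any claim that something is new, unique, unknown or untested is made for them only; others in the source may bear on it.

Measured so far:
- compound 1, `COc1cc(/C=C/C(=O)c2sc(Nc3ccccc3C)nc2C)cc(OC)c1OC`: > 25000 nM, a limit of the assay rather than a number
- compound 2, `Cc1nc(Nc2ccccc2)sc1C(=O)/C=C/c1ccccc1`: > 25000 nM, likewise a limit and not a number

Both measurements come from a functional assay on PC-3 cells (Homo sapiens) for cytotoxicity, read by MTT assay; on this read-out higher numbers stand for weaker inhibition and lower numbers for stronger inhibition. Compound 1 stands at the limit of that assay, with no numerical potency recorded for it. Compound 2 stands at the same limit. Every value shown is therefore a limit: the limit of > 25000 nM in this assay, at which 2 of the 2 values shown sit. Among the measured compounds shown here, no pair of measured compounds differs in a single place, so no measured step gives a sense of how far a small change can move the read-out here.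

The unmeasured compound 3, `COc1cc(/C=C/C(=O)c2sc(Nc3ccccc3)nc2C)cc(OC)c1OC`, differs from compound 1 by hydrogen in place of methyl on an aromatic carbon. With compound 1 at the limit and no comparison at hand, a step in this assay beyond the scatter is not expected in either direction; the most plausible outcome is that compound 3 also fails to reach a measurable value. Compound 3 is thus expected to give 25000 nM, with a range from 10000 nM to 100000 nM, most likely reported again as a limit. The expected step, a number no higher from compound 1 to compound 3 (the limit leaves the size open), lies within the scatter.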

Compound 3, half-maximal inhibitory concentration: > 25000 nM
Compound 3: no number, only a limit (the forecaster's own chance of this, stated with the estimate: 80%); the middle value lies on the limit itself.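

Compound 1 and compound 3 each give only a limit and not a number, so the step between them cannot be read: the limit of > 25000 nM in this assay, at which 3 of the 3 values shown sit. The compounds shown leave open whether hydrogen in place of methyl on that aromatic carbon moves the read-out at all, and which change, if any, would yield a measurable value.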